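A Single Methyl on the Chain of Compound 1

The compounds below may be only part of what the source reports. "The series", "measured", "known", "first", "only" and "open" are said of these compounds alone.

Values so far in a functional assay on A549 cells (Homo sapiens) for antiproliferative activity, read by sulforhodamine B assay, with a stated time of 72 h (a higher number here means a weaker inhibitor, a lower number a stronger inhibitor), are these

Compound 1 `CC(C)C[C@H](NC(=O)CSc1cc(NS(=O)(=O)c2cccs2)c2ccccc2c1O)B(O)O` gives 7540 nM
Compound 2 `CC(C)C[C@H](NC(=O)C(C)Sc1cc(NS(=O)(=O)c2ccccc2)c2ccccc2c1O)B(O)O` gives 4560 nM; 4480 nM (2 entries)
Compound 3 `CC(C)C[C@H](NC(=O)C(C)Sc1cc(NS(=O)(=O)c2ccc(Cl)cc2)c2ccccc2c1O)B(O)O` gives 12800 nM; 16500 nM (2 entries)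

Compound 1 is the only one of the three that rests on a single reading, whereas compound 2 and compound 3 have two entries each. Compound 4 `CC(C)C[C@H](NC(=O)C(C)Sc1cc(NS(=O)(=O)c2cccs2)c2ccccc2c1O)B(O)O` has not yet been measured. It departs from compound 1 by one change (methyl in place of hydrogen on a saturated chain carbon bound to a carbonyl carbon and a sulfur), methyl in place of hydrogen on a saturated chain carbon bound to a carbonyl carbon and a sulfur. Within the data shown here, no measured pair isolates this change. Compound 2 at 4560 nM; 4480 nM (2 entries) and compound 3 at 12800 nM; 16500 nM (2 entries) already carry that methyl, and neither value suggests a large shift. In this assay the estimated result is a 1.3-fold lower number from compound 1 to compound 4 (0.10 log units; within the scatter) and this expected step is not thought to go beyond the usual scatter in either direction. For compound 4 the expected value is 6000 nM (estimated range 2500 nM to 14000 nM).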

Compound 4, half-maximal inhibitory concentration: 11300 nM
Compound 4: middle estimate off by 1.9-fold (0.27 log units), on the low side, within the range that was stated.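

In this assay the direct pair gives a 1.5-fold higher number from compound 1 to compound 4 (0.18 log units; within the scatter), so neither a gain nor a loss can be claimed for methyl in place of hydrogen on a saturated chain carbon bound to a carbonyl carbon and a sulfur. The earlier compounds shown here could not show this, since compound 2 and compound 3 both carry the methyl and have no partner without it. The pair has only one reading on each side, while the methyl-bearing compounds with repeats show how closely two entries can agree or differ: the several entries of compound 2 in this assay, 4560 nM; 4480 nM (2 entries)

The compounds shown leave open whether this small tolerance extends to an ethyl group, a second methyl or a carboxylic acid on the same carbon. Among these compounds, they also leave open whether the same change gives a similar step on any other sulfonamide group, as this one pair is the only direct evidence.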